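Solubility across an aminopyridine-substituted shared core

The compounds below may be only part of what the source reports. "The series", "measured", "known", "first", "only" and "open" are said of these compounds alone.

Measured so far:
- compound 1, `FC(F)(F)c1cccc(-c2nc3cnc(Nc4ncccn4)cc3[nH]2)c1`: 155000 nM
- compound 2, `Fc1ccc(Nc2cc3[nH]c(-c4ccc(F)c(F)c4)nc3cn2)nc1`: 42000 nM

In a physicochemical assay for solubility, using the shake flask method, measured as kinetic solubility, with a stated time of 20 h, at pH 2 (on this read-out lower numbers stand for lower solubility and higher numbers for higher solubility), compound 1 gives 155000 nM, the highest of the two numbers. Among the measured compounds shown here, compound 2 gives 42000 nM in this assay, a lower number that lies beyond the scatter; no single-point step between these two is recorded, so only the two values themselves are compared here.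

Compound 3, `NC(=O)c1ccc(Nc2cc3[nH]c(-c4cccc(C(F)(F)F)c4)nc3cn2)nc1`, is not yet measured. It differs from compound 1 in one place: 5-carbamoylpyridin-2-yl in place of pyrimidin-2-yl on a nitrogen on an aromatic ring. For the measured compounds named here, the pairs measured so far give no step that bears directly on this change, so the expectation rests on compound 1 alone.

Compound 3 is expected to stay close to compound 1, with an estimated step of a 1.3-fold higher number from compound 1 to compound 3 (0.11 log units; within the scatter), which lies within the usual scatter. The estimate for compound 3 in this assay is 200000 nM, with a range from 60000 nM to 600000 nM.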

Compound 3, solubility: < 5000 nM
Compound 3 was reported as a limit; the forecaster's own chance of this, stated with the estimate: 5%; middle value at least 40-fold (1.60 log units) from the limit.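

With the rest of compound 1 kept, 5-carbamoylpyridin-2-yl in place of pyrimidin-2-yl on a nitrogen on an aromatic ring comes with an at least 31-fold lower number from compound 1 to compound 3 (1.49 log units; beyond the scatter) in this assay. This is the only single-place step shown so far, and it places a read-out change beyond the scatter at this position. The value of compound 3 is a limit and not a number, so the step fixes only a minimum size: the limit of < 5000 nM in this assay, at which 1 of the 3 values shown sits.

The ring changes and the carbamoyl group enters together, so this pair does not separate the two. The compounds shown leave open how an unsubstituted pyridin-2-yl, or a pyridin-2-yl carrying a nitrile or a carboxylic acid in place of the carbamoyl group, would read in this assay.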